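Series notes: amine tail variations on a shared core

A few compounds are considered here, and "the series" means these few. Any claim that something is new, unique, unknown or untested is made for them only; others in the source may bear on it.

Measured in an assay on HeLa cells for inhibition of sphingosine-1-phosphate transporter SPNS2 (Mus musculus), read by LC-MS, tested at 2 uM; a lower number here means less inhibition, a higher number more inhibition at the concentration tested (going by the name of the read-out):
compound 1 `CCCCCCCCCCc1ccc(-c2noc(CN)n2)cc1` gives 62%
compound 2 `CCCCCCCCCCc1ccc(-c2noc(CCCN)n2)cc1` gives 67%
compound 3 `CCCCCCCCCCc1ccc(-c2noc(CC3CCNC3)n2)cc1` gives 44%

Compound 3 stands lowest of the three measured numbers; the steps of a number 18 percentage points lower from compound 1 to compound 3 (beyond the scatter) and a number 23 percentage points lower from compound 2 to compound 3 (beyond the scatter) both lie beyond the scatter, while a number 5 percentage points higher from compound 1 to compound 2 (within the scatter) lies within it. Compound 4 `CCCCCCCCCCc1ccc(-c2noc(CC(O)CN)n2)cc1` is not yet measured in this assay. Its change from compound 3 is 2-amino-1-hydroxyethyl in place of pyrrolidin-3-yl on a saturated chain carbon bound to an aromatic carbon. The two steps into compound 3 bear on this directly: both open-chain amines gave higher inhibition than the pyrrolidin-3-yl, and compound 4 returns to an open-chain amine. A step back upward beyond the scatter is therefore expected, a number 16 percentage points higher from compound 3 to compound 4 (beyond the scatter). For compound 4 the estimate is 60% with a range of 45% to 75%.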

Compound 4, a percentage reported as inhibition, at one concentration (the size of the read-out at that concentration, not a potency): 59%
Estimate against measurement, compound 4: 1 percentage points above; the range from low to high includes it.
By their numbers in this assay, from the lowest: compound 3; then compounds 4, 1 and 2 (each within the scatter of the next).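

Within this assay, the pyrrolidin-3-yl is the tail that stands apart: an open-chain amine carrying a hydroxy group restores the read-out (a number 15 percentage points higher from compound 3 to compound 4 (beyond the scatter)). The hydroxy itself makes no difference that can be read (a number 8 percentage points lower from compound 2 to compound 4 (within the scatter)), and the 2-amino-1-hydroxyethyl tail also stays within the scatter of the shorter amine (a number 3 percentage points lower from compound 1 to compound 4 (within the scatter)). No available evidence accounts for any of these steps.

As far as these compounds go, whether a dimethylamino group or a carboxylic acid in place of the terminal amine would hold the number stays open. A single-concentration read-out also leaves potency across these tails unresolved.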